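This account rests on a few compounds, and the source may have more. Where it says the series, first, only, none or still open, it means among the compounds named here.

Measured in a functional assay on P388 cells (Mus musculus) for inhibition; on this read-out lower numbers stand for stronger inhibition and higher numbers for weaker inhibition:
Compound 1 `COc1ccc(/C=C/c2ccc3ccccc3c2)cc1`: > 5000 nM
Compound 2 `COc1ccc(/C=C/c2ccc3ccccc3c2)cc1[N+](=O)[O-]`: > 5000 nM
Compound 3 `COc1ccc(/C=C/c2ccc3ccccc3c2)cc1N`: > 5000 nM

Compound 3 gives > 5000 nM, which is a limit and not a number. It is not alone there, as the set shows (the limit of > 5000 nM in this assay, at which 3 of the 3 values shown sit). The next compound, compound 4 `CCN(CC)c1cc(/C=C/c2ccc3ccccc3c2)ccc1OC`, carries diethylamino in place of amino on an aromatic carbon, ortho to a methoxy group: diethylamino in place of amino on an aromatic carbon. The steps nearest to this change are a step that the two limits leave unreadable from compound 1 to compound 3 and a step that the two limits leave unreadable from compound 2 to compound 3, and the remaining one is a step that the two limits leave unreadable from compound 1 to compound 2. None of them has a readable size, so no shift in either direction can be carried over, and no move beyond the scatter is expected. The expected step is a step that the limit leaves unreadable from compound 3 to compound 4. For compound 4 the estimate is 8000 nM, with an expected range from 2500 nM to 25000 nM.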

Compound 4, half-maximal inhibitory concentration: > 5000 nM
Compound 4 ended at the assay's limit; the forecaster's own chance of this, stated with the estimate: 85%; the middle value lies beyond the limit too.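

Compound 4, like compound 1, compound 2 and compound 3, sits at a limit in this assay, so no step among these compounds can be read: the limit of > 5000 nM in this assay, at which 4 of the 4 values shown sit.

The compounds shown leave open how strongly any of them inhibits, and whether any of these groups on the shared core changes that.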